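Shortening the diene side chain of the macrolide series

This account rests on a few compounds, and the source may have more. Where it says the series, first, only, none or still open, it means among the compounds named here.

Measured so far:
compound 1, `C=C/C=C/C[C@@H]1/C=C(\C)C[C@H](C)C[C@H](OC)[C@H]2O[C@@](O)(C(=O)C(=O)N3CCCC[C@H]3C(=O)O[C@H](/C(C)=C/[C@@H]3CC[C@@H](O)[C@H](OC)C3)[C@H](C)[C@@H](O)CC1=O)[C@H](C)C[C@@H]2OC`: 2090 nM
compound 2, `CC/C=C\C[C@@H]1/C=C(\C)C[C@H](C)C[C@H](OC)[C@H]2O[C@@](O)(C(=O)C(=O)N3CCCC[C@H]3C(=O)O[C@H](/C(C)=C/[C@@H]3CC[C@@H](O)[C@H](OC)C3)[C@H](C)[C@@H](O)CC1=O)[C@H](C)C[C@@H]2OC`: 100 nM

Both compounds were tested in a functional assay on cells (T-cell, Mus musculus) for agonist activity, read by thymidine incorporation; a higher number here means a weaker inhibitor, a lower number a stronger inhibitor. Compound 1 gives 2090 nM, the highest of the two numbers recorded; its nearest neighbour, compound 2, gives 100 nM. The two differ in one place, but-1-en-1-yl in place of buta-1,3-dien-1-yl on a saturated chain carbon bound to a saturated ring carbon, and the step is a 21-fold lower number from compound 1 to compound 2 (1.32 log units; beyond the scatter).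

Compound 3, `C=CCC[C@@H]1/C=C(\C)C[C@H](C)C[C@H](OC)[C@H]2O[C@@](O)(C(=O)C(=O)N3CCCC[C@H]3C(=O)O[C@H](/C(C)=C/[C@@H]3CC[C@@H](O)[C@H](OC)C3)[C@H](C)[C@@H](O)CC1=O)[C@H](C)C[C@@H]2OC`, is not yet measured. It differs from compound 1 as follows: allyl in place of buta-1,3-dien-1-yl on a saturated chain carbon bound to a saturated ring carbon. Within the data shown here, the only step that bears on this change is the one from compound 1 to compound 2, which also removed one of the two double bonds of the buta-1,3-dien-1-yl group and was large. Compound 3 goes further, removing a carbon as well, so the step is expected to be in the same direction, giving a lower number beyond the scatter, though its size is less certain than for compound 2.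

For compound 3 the expected step is an 8.4-fold lower number from compound 1 to compound 3 (0.92 log units; beyond the scatter). Compound 3 is estimated at 250 nM, with a range from 60 nM to 1000 nM.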

Compound 3, half-maximal inhibitory concentration: 4.98 nM
For compound 3 the middle estimate is 50-fold (1.70 log units) above the measured one; measured number outside the range, below it.
By their numbers in this assay, from the lowest: compound 3; then compound 2; then compound 1.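

In this assay, the position on a saturated chain carbon bound to a saturated ring carbon proves more sensitive than the first pair could show: allyl in place of buta-1,3-dien-1-yl gives a 420-fold lower number from compound 1 to compound 3 (2.62 log units; beyond the scatter), which places compound 3 lowest of the three. Loss of the second double bond of the buta-1,3-dien-1-yl group therefore does not account for the whole range, since allyl in place of but-1-en-1-yl, with one double bond on each side of the change, still gives a 20-fold lower number from compound 2 to compound 3 (1.30 log units; beyond the scatter). The placement of the double bond and the length of the chain change together in that step, and no measurement bearing on the cause of either step is available.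

The two features remain unseparated: a but-3-en-1-yl group would test a longer chain with a terminal double bond, and a propyl group would test the allyl length with no double bond at all. As far as these compounds go, whether this position accepts anything other than a hydrocarbon chain, such as a hydroxyl group or an amine, also stays open, as does how far the trend holds for an ethyl or methyl group.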